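The compounds below may be only part of what the source reports. "The series", "measured", "known", "first", "only" and "open" are said of these compounds alone.

Measured compounds in an assay on DDT1 cells (Cricetulus griseus) for binding affinity to adenosine receptor A1 (Homo sapiens), read by radioligand binding; on this read-out lower numbers stand for stronger inhibition and higher numbers for weaker inhibition:
- compound 1 `C/N=C(\S)OC[C@H]1OC(n2cnc3c(NC4CCOC4)ncnc32)[C@H](O)[C@@H]1O`: 45 nM
- compound 2 `CCNC(=O)OC[C@H]1OC(n2cnc3c(NC4CCOC4)ncnc32)[C@H](O)[C@@H]1O`: 167 nM
- compound 3 `CC/N=C(\S)OC[C@H]1OC(n2cnc3c(NC4CCOC4)ncnc32)[C@H](O)[C@@H]1O`: 33 nM

Compound 3 has the lowest number of the three in this assay. Its nearest neighbour is compound 1, and a 1.4-fold lower number from compound 1 to compound 3 (0.13 log units; within the scatter) lies within the scatter, so the two cannot be ordered. Compound 2 stands furthest away, as a 5.1-fold lower number from compound 2 to compound 3 (0.70 log units; beyond the scatter) shows.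

Compound 4 `CCCNC(=O)OC[C@H]1OC(n2cnc3c(NC4CCOC4)ncnc32)[C@H](O)[C@@H]1O` differs from compound 3 in one place: a group of 6 heavy atoms (4 carbon, 1 nitrogen, 1 oxygen; no ring) in place of a group of 5 heavy atoms (3 carbon, 1 nitrogen, 1 sulfur; no ring), on an oxygen on a saturated carbon. For the measured compounds named here, two measured steps bear on this exchange, since each swaps a sulfur-bearing group of the same kind for a carbamoyl group or back. Going one way, a 3.7-fold higher number from compound 1 to compound 2 (0.57 log units; beyond the scatter); going the other way, a 5.1-fold lower number from compound 2 to compound 3 (0.70 log units; beyond the scatter). Both are modest and beyond the scatter, and both put the carbamoyl member at the higher number. Going by the values given here, the extra chain carbon in propylcarbamoyl has no direct counterpart, but a 1.4-fold lower number from compound 1 to compound 3 (0.13 log units; within the scatter) suggests a single added carbon matters little.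

Compound 4 is therefore expected to show a 4.5-fold higher number from compound 3 to compound 4 (0.66 log units; beyond the scatter). The estimate for compound 4 in this assay is 150 nM, within a range of 70 nM to 350 nM.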

Compound 4, inhibition constant: 235 nM
The estimate for compound 4 lay 1.6-fold (0.19 log units) below the measured number; the measured number falls inside the stated range.
By their numbers in this assay, from the lowest: compounds 3 and 1 (each within the scatter of the next); then compounds 2 and 4 (each within the scatter of the next).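

Exchanging a sulfur-bearing group for propylcarbamoyl on this oxygen gave a 7.1-fold higher number from compound 3 to compound 4 (0.85 log units; beyond the scatter) in this assay, and the shorter sulfur-bearing group showed the same direction, with a 5.2-fold higher number from compound 1 to compound 4 (0.72 log units; beyond the scatter). Within the carbamoyl pair, the added methyl gave only a 1.4-fold higher number from compound 2 to compound 4 (0.15 log units; within the scatter), so this chain extension has now been read in both pairs, and the two readings agree: the same change on two cores in this assay, a 1.4-fold lower number (0.13 log units; within the scatter) from compound 1 to compound 3 and a 1.4-fold higher number (0.15 log units; within the scatter) from compound 2 to compound 4, 1.9-fold (0.28 log units) apart, within the scatter of two such steps Among these four compounds, the exchange of the sulfur-bearing group for the carbamoyl group, not the added methyl, is what separates the numbers.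

The compounds shown leave open whether a butyl chain or any longer chain would keep this pattern in either pair. They also leave open how an amine or a carboxylic acid on this oxygen would compare.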